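From compound 2 to compound 3: a difluorophenyl swap

This account rests on a few compounds, and the source may have more. Where it says the series, first, only, none or still open, it means among the compounds named here.

Compound 1 `CC(C)[C@H](NC(=O)c1cc(Cl)ccc1OCCNC(=O)OC(C)(C)C)C(=O)Nc1ccc(C(F)(F)F)cc1Cl`: > 10000 nM (a limit of the assay)
Compound 2 `CC(C)[C@H](NC(=O)c1cc(Cl)ccc1OCCNC(=O)OC(C)(C)C)C(=O)Nc1cc(F)cc(C(F)(F)F)c1`: 11500 nM

Going by the values given here, in a functional assay on MCF7 cells (Homo sapiens) for inhibition, read by MTT assay, with a stated time of 72 h (on this read-out lower numbers stand for stronger inhibition and higher numbers for weaker inhibition), compound 2 gives the only actual number so far, 11500 nM. Compound 1 gives only a limit, > 10000 nM, and not a number.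

Compound 3 `CC(C)[C@H](NC(=O)c1cc(Cl)ccc1OCCNC(=O)OC(C)(C)C)C(=O)Nc1ccc(F)c(F)c1` keeps the shared core of compound 2 and carries 3,4-difluorophenyl in place of 3-fluoro-5-(trifluoromethyl)phenyl on an amide-type nitrogen. Among the compounds with values here, the one measured step at this place is a step that the limit leaves unreadable from compound 1 to compound 2. Its size cannot be read, so it offers no measure for the new change. With compound 2 at 11500 nM as the sole anchor, no shift beyond the scatter is expected in this assay. Another limit would be no surprise. The estimated change is a 1.2-fold higher number from compound 2 to compound 3 (0.09 log units; within the scatter). Compound 3 is expected at 14000 nM, with an estimated range of 6000 nM to 35000 nM.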

Compound 3, half-maximal inhibitory concentration: > 10000 nM
Compound 3 gave a limit, no number (the forecaster's own chance of this, stated with the estimate: 45%); the middle value does not contradict the limit.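

No step from compound 1 or compound 2 to compound 3 can be read in this assay, because compound 3 gives only a limit: the limit of > 10000 nM in this assay, at which 2 of the 3 values shown sit.

The compounds shown leave open whether either change on the amide-type nitrogen moves the value beyond the usual scatter.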